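A few compounds are considered here, and "the series" means these few. Any claim that something is new, unique, unknown or untested is made for them only; others in the source may bear on it.

Measured compounds in a functional assay on Ehrlich cells (Mus musculus) for cytotoxicity, read by trypan blue exclusion, with a stated time of 2 h, tested at 100 ug/mL; a higher number here means a stronger effect of the compound at the concentration tested, a lower number a weaker effect:
- compound 1 `COc1ccccc1C1C(C#N)=C(N)N(c2ccc(S(N)(=O)=O)cc2)C2=C1CCCC2` gives 100%
- compound 2 `N#CC1=C(N)N(c2ccc(S(N)(=O)=O)cc2)C2=C(CCCC2)C1c1ccc(Cl)cc1Cl` gives 70%

Compound 1 stands highest of the two numbers; its nearest neighbour is compound 2, with a number 30 percentage points lower from compound 1 to compound 2 (beyond the scatter) separating them, a step beyond the scatter.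

Compound 3 `N#CC1=C(N)N(c2ccc(S(N)(=O)=O)cc2)C2=C(CCCC2)C1c1ccc(Cl)c(Cl)c1` is not yet measured. Its change from compound 1 is 3,4-dichlorophenyl in place of 2-methoxyphenyl on a saturated ring carbon. Within the data shown here, the one measured step that bears on this is the exchange of the same 2-methoxyphenyl group on the same saturated ring carbon for a dichlorophenyl group, which gave a number 30 percentage points lower from compound 1 to compound 2 (beyond the scatter). Among the measured compounds shown here, compound 3 carries a dichlorophenyl group of a different substitution pattern, so a downward step of similar size is expected in this assay, though the exact size is uncertain with only one comparison available.

The step from compound 1 to compound 3 is therefore expected to be a number 28 percentage points lower from compound 1 to compound 3 (beyond the scatter). Compound 3 is estimated at 72%, within a range of 50% to 100%.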

Compound 3, a percentage reported as activity, at one concentration (the size of the read-out at that concentration, not a potency): 50%
Compound 3: middle estimate off by 22 percentage points, on the high side; the range from low to high includes it.
By their numbers in this assay, from the lowest: compound 3; then compound 2; then compound 1.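

Compound 3 is the lowest of the three in this assay, with a number 50 percentage points lower from compound 1 to compound 3 (beyond the scatter). With 3,4-dichlorophenyl in place of 2,4-dichlorophenyl on the saturated ring carbon, the read-out shows a number 20 percentage points lower from compound 2 to compound 3 (beyond the scatter), so this position responds to where the two chlorines sit on the phenyl ring and not only to which substituent it carries. Nothing available here accounts for this difference.

The compounds shown leave open whether the higher read-out of compound 1 belongs to the methoxy group itself or to its place on the ring, which 4-methoxyphenyl or 3-methoxyphenyl at this carbon would separate. They also leave open how unsubstituted phenyl, or a single chlorine as in 2-chlorophenyl or 4-chlorophenyl, would compare with the two dichlorophenyl groups.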